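Swapping a methylsulfonyl for chloro on a thioamide chromene

This account rests on a few compounds, and the source may have more. Where it says the series, first, only, none or still open, it means among the compounds named here.

Measured so far:
compound 1 `C/N=C(/S)C1=CC(C)(C)Oc2ccc(S(=O)(=O)c3ccccc3)cc21` gives 19.5 nM
compound 2 `C/N=C(/S)C1=CC(C)(C)Oc2ccc(S(C)(=O)=O)cc21` gives 490 nM

Both measurements come from a functional assay (aorta) with Rattus norvegicus as the target; a lower number here means that less compound is needed, a higher number that more compound is needed for the effect. Compound 2 stands at the higher of the two numbers, and its nearest neighbour is compound 1, the step being a 25-fold higher number from compound 1 to compound 2 (1.40 log units; beyond the scatter); that step exchanges one group on a sulfonyl sulfur and is large.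

Compound 3 `C/N=C(/S)C1=CC(C)(C)Oc2ccc(Cl)cc21` has not yet been measured. It differs from compound 2 in one place: chloro in place of methylsulfonyl on an aromatic carbon. Among the compounds with values here, the only measured step that bears on this position is the one from compound 1 to compound 2, and it shows that the group here matters strongly to the read-out. Within the data shown here, no measured pair, however, removes the sulfonyl group altogether or introduces a halogen, so the direction of the present change cannot be read from the data with any confidence. The expectation is therefore a step of uncertain direction, of the order of a 1.6-fold lower number from compound 2 to compound 3 (0.21 log units; within the scatter), with a wide spread. Compound 3 is estimated at 300 nM, between 60 nM and 1500 nM.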

Compound 3, half-maximal effective concentration: 28.8 nM
For compound 3 the middle estimate is 10-fold (1.02 log units) above the measured one; the measured number lies below the stated range.
By their numbers in this assay, from the lowest: compounds 1 and 3 (each within the scatter of the next); then compound 2.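

In this assay, putting chloro in place of methylsulfonyl on the aromatic carbon gives a 17-fold lower number from compound 2 to compound 3 (1.23 log units; beyond the scatter), so a sulfonyl group at this position is not required for a low number: a single chlorine atom, with no hydrogen-bond acceptors, serves as well. Compound 1 at 19.5 nM and compound 3 at 28.8 nM lie within the usual scatter of each other, so phenylsulfonyl and chloro, two very different groups, cannot be told apart here, and the methylsulfonyl of compound 2 is the one that stands apart. Nothing measured on these compounds beyond this read-out is available to explain why methylsulfonyl stands apart.

The compounds shown leave open whether other groups on this carbon, such as fluoro, bromo, nitrile or methoxy, would follow chloro or methylsulfonyl, and what plain hydrogen there would give. They also leave open whether chloro and phenylsulfonyl would remain level if the sulfur of the thioamide side chain were replaced by the oxygen of an amide.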